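Notes on a bromo to trifluoromethyl exchange

This account rests on a few compounds, and the source may have more. Where it says the series, first, only, none or still open, it means among the compounds named here.

Values in a functional assay on B16 cells (Mus musculus) for antiproliferative activity, read by MTT assay, with a stated time of 24 h; a lower number here means a stronger inhibitor, a higher number a weaker inhibitor:
- compound 1 `COc1cc(OC)c(-c2coc3cc(OCC=C(C)C)ccc3c2=O)cc1OC` gives 1090 nM
- compound 2 `COc1cc(OC)c(-c2coc3cc(OCc4cccc(Br)c4)ccc3c2=O)cc1OC` gives 4400 nM

Compound 2 holds the higher of the two numbers, so it is the weaker inhibitor of the pair. Compound 3 `COc1cc(OC)c(-c2coc3cc(OCc4cccc(C(F)(F)F)c4)ccc3c2=O)cc1OC` differs from compound 2 by one exchange, (trifluoromethyl in place of bromo on an aromatic carbon), with trifluoromethyl in place of bromo on an aromatic carbon. Within the data shown here, the only measured step, a 4.0-fold higher number from compound 1 to compound 2 (0.61 log units; beyond the scatter), changed a larger part of the molecule and bears on this exchange only loosely. No step beyond the scatter is therefore expected in this assay. The expected result is a 1.1-fold lower number from compound 2 to compound 3 (0.04 log units; within the scatter). Compound 3 is estimated at 4000 nM, within an expected range of 1800 nM to 9000 nM.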

Compound 3, half-maximal inhibitory concentration: > 10000 nM
Compound 3 ended at the assay's limit; the forecaster's own chance of this, stated with the estimate: 5%; at least 2.5-fold (0.39 log units) between middle value and limit.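

In this assay compound 3 gives > 10000 nM, which is a limit of the assay and not a number: the limit of > 10000 nM in this assay, at which 1 of the 3 values shown sits. On this aromatic carbon, the exchange of bromo for trifluoromethyl alone gives an at least 2.2-fold higher number from compound 2 to compound 3 (0.35 log units; beyond the scatter), so this single change is enough to move the read-out beyond the scatter. The wider change on the saturated chain carbon, to 3-(trifluoromethyl)phenyl from 2-methylprop-1-en-1-yl, gives an at least 9.1-fold higher number from compound 1 to compound 3 (0.96 log units; beyond the scatter).

Going by these compounds, how far compound 3 lies past the limit stays open. Also open, on these data alone, is what an amine or a carboxylic acid on the same aromatic carbon would give.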